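A few compounds are considered here, and "the series" means these few. Any claim that something is new, unique, unknown or untested is made for them only; others in the source may bear on it.

Measured so far in a functional assay on the whole organism (Pleural cavity) with Rattus norvegicus as the target; on this read-out higher numbers stand for an effect only at larger amounts of compound and lower numbers for an effect already at smaller amounts:
compound 1 `OC[C@H]1O[C@@H](n2cnc3c(NCc4ccccc4)nccc32)C[C@@H]1O` gives > 9 mg/kg
compound 2 `OC[C@H]1OC(n2cnc3c(NCc4ccccc4)nccc32)[C@H](O)[C@@H]1O` gives > 9 mg/kg
compound 3 `c1ccc(CSc2[nH]ccc3ncnc2-3)cc1` gives > 9 mg/kg

Each of these three values is a limit of the assay, not a number. Compound 1 therefore stands at the limit of > 9 mg/kg in this assay, at which 3 of the 3 values shown sit, and nothing sets it apart from the other two. Among the measured compounds shown here, no step between measured compounds can be worked out from limits alone.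

Compound 4 `OC[C@H]1O[C@@H](n2cnc3cnccc32)C[C@@H]1O` is the untested compound. Compared with compound 1 the change is hydrogen in place of benzylamino on an aromatic carbon. With compound 1 already at a limit, the step that the limit leaves unreadable from compound 1 to compound 4 in this assay is expected to stay within the scatter, most likely again as a limit. For compound 4 the estimate is 15 mg/kg, within a range from 6 mg/kg to 40 mg/kg.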

Compound 4, dose for half-maximal effect: > 9 mg/kg
Compound 4 gave a limit, no number (the forecaster's own chance of this, stated with the estimate: 85%); the middle value does not contradict the limit.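

Among the compounds shown here, compound 1 and compound 4 both end at a limit rather than a number, so no step between them can be read: the limit of > 9 mg/kg in this assay, at which 4 of the 4 values shown sit. As far as these compounds go, whether hydrogen in place of benzylamino changes the effect in this assay at all stays open.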